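This account rests on a few compounds, and the source may have more. Where it says the series, first, only, none or still open, it means among the compounds named here.

Among the compounds with values here, compound 2 `COc1c(OCCCCN2CCN(C)CC2)cc(O)c2c(=O)cc(-c3ccc(C(F)(F)F)cc3)oc12` is one of only two compounds measured in a functional assay on B16 cells (Mus musculus) for cytotoxicity, read by MTT assay, with a stated time of 72 h; on this read-out higher numbers stand for weaker inhibition and lower numbers for stronger inhibition. In this assay compound 2 gives 4990 nM, the higher of the two numbers, while compound 1 `COc1ccc(-c2cc(=O)c3c(O)cc(OCCCCN4CCN(C)CC4)c(OC)c3o2)cc1` gives 4100 nM. The step of a 1.2-fold higher number from compound 1 to compound 2 (0.09 log units; within the scatter) stayed within the scatter, so on the numbers shown the two compounds are not told apart. Compound 3 `COc1ccccc1-c1cc(=O)c2c(O)cc(OCCCCN3CCN(C)CC3)c(OC)c2o1` has not been measured yet; it differs from compound 2 by 2-methoxyphenyl in place of 4-(trifluoromethyl)phenyl on an aromatic carbon. Within the data shown here, the single measured step, a 1.2-fold higher number from compound 1 to compound 2 (0.09 log units; within the scatter), involves a different substituent than the one now entering, so it bears only loosely on this change; it suggests that exchanging the substituent of this outer ring leaves this assay roughly unchanged. No step beyond the scatter is therefore expected. Compound 3 is estimated at 4500 nM, between 1500 nM and 13500 nM, an expected step of a 1.1-fold lower number from compound 2 to compound 3 (0.04 log units; within the scatter).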

Compound 3, half-maximal inhibitory concentration: 9300 nM
Beside the measured number, compound 3's estimate is 2.1-fold (0.32 log units) below it, and the stated range covers the measured number.
By their numbers in this assay, from the lowest: compounds 1, 2 and 3 (each within the scatter of the next, the first and the last beyond it).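

Within the data shown here, compound 1 and compound 3 differ only in having 4-methoxyphenyl or 2-methoxyphenyl at this position, and a 2.3-fold higher number from compound 1 to compound 3 (0.36 log units; beyond the scatter) is the first step here to pass the scatter, if only modestly. So in this assay, where the methoxy group sits on this outer ring can shift the number, which the exchange of one substituent for another between compound 1 and compound 2 did not show. Against the trifluoromethyl compound the picture is less clear, since a 1.9-fold higher number from compound 2 to compound 3 (0.27 log units; within the scatter) does not separate the pair, and nothing measured here offers a reason for the shift.

On these data alone, it remains open whether an amine or a carboxylic acid on this outer ring, or a longer chain in place of the methoxy group, would move the number further. As far as these compounds go, whether the step between compound 1 and compound 3 holds outside this assay also stays open.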